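Removing the Trifluoromethyl Group: Expectation for Compound 4

The source may report more compounds than this note shows. Statements on the series, on what has been measured and on what is new or still open speak of the compounds shown alone.

Of the compounds shown here, three sharing one core have been measured in a functional assay on HepG2 cells (Homo sapiens) for cytotoxicity, read by MTT assay, with a stated time of 48 h; on this read-out lower numbers stand for stronger inhibition and higher numbers for weaker inhibition. Compound 1 `COC(=O)/C=C/c1ccc2c(c1)C(=O)C(=O)N2Cc1ccc(Cl)c(Cl)c1` gives 160 nM. Compound 2 `COC(=O)/C=C/c1ccc2c(c1)C(=O)C(=O)N2Cc1ccc(OC)cc1` gives 30 nM, and compound 3 `COC(=O)/C=C/c1ccc2c(c1)C(=O)C(=O)N2Cc1ccc(C(F)(F)F)cc1` gives 70 nM. Among these three numbers, compound 3 holds the second highest; compound 1 sits nearest to it and compound 2 furthest. The measured steps were a 5.3-fold lower number from compound 1 to compound 2 (0.73 log units; beyond the scatter) and a 2.3-fold higher number from compound 2 to compound 3 (0.37 log units; beyond the scatter), both modest. In both of them the change is in what sits on the six-membered aromatic ring of carbon only.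

Compound 4 `COC(=O)/C=C/c1ccc2c(c1)C(=O)C(=O)N2Cc1ccccc1` differs from compound 3 in one place: hydrogen in place of trifluoromethyl on an aromatic carbon. Within the data shown here, no measured step removes a group to leave hydrogen, so the expectation rests mainly on a 2.3-fold higher number from compound 2 to compound 3 (0.37 log units; beyond the scatter), which shows that exchanging one group for another at this place moves the number modestly. A step of similar or smaller size is therefore expected in this assay, in either direction, and possibly none beyond the scatter. Compound 4 is estimated at 60 nM, within 25 nM to 150 nM, which means an expected step of a 1.2-fold lower number from compound 3 to compound 4 (0.07 log units; within the scatter).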

Compound 4, half-maximal inhibitory concentration: 40 nM
For compound 4 the middle estimate is 1.5-fold (0.18 log units) above the measured one; the measured number falls inside the stated range.
By their numbers in this assay, from the lowest: compounds 2, 4 and 3 (each within the scatter of the next, the first and the last beyond it); then compound 1.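

In this assay, compound 4 shows that this place on the ring can carry plain hydrogen without a step beyond the scatter, whether hydrogen replaces trifluoromethyl (a 1.8-fold lower number from compound 3 to compound 4 (0.24 log units; within the scatter)) or methoxy (a 1.3-fold higher number from compound 2 to compound 4 (0.12 log units; within the scatter)). So although compound 2 and compound 3 differ beyond the scatter, neither group separates clearly from hydrogen, and of the groups shown only the 3,4-dichlorophenyl does (a 4.0-fold lower number from compound 1 to compound 4 (0.60 log units; beyond the scatter)). Nothing at hand explains why these steps have the sizes they do.

The compounds shown leave open what an amine, a carboxylic acid or a longer chain would do at this place on the ring. They also leave open whether a single chlorine would behave like the 3,4-dichlorophenyl or like plain phenyl.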